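The source may report more compounds than this note shows. Statements on the series, on what has been measured and on what is new or still open speak of the compounds shown alone.

Of the compounds shown here, three of one series have so far been read in an assay on T-REx-293 cells for inhibition of potassium channel subfamily T member 1 (Homo sapiens), read by patch clamp; on this read-out higher numbers stand for weaker inhibition and lower numbers for stronger inhibition. Compound 1 `C[C@H](NC(=O)c1cc(C2CC2)nn1C)c1nc(-c2ccccc2)no1` gives 11400 nM. Compound 2 `CCc1cc(C(=O)N[C@@H](C)c2nc(-c3cccc(C)c3)no2)n(C)n1` gives 335 nM. For compound 3 `Cc1cccc(-c2noc([C@H](C)NC(=O)c3cc(C(F)(F)F)nn3C)n2)n1` this assay reports only a limit, > 30000 nM, and not a number. That limit is the limit of > 30000 nM in this assay, at which 1 of the 3 values shown sits. Of the three values shown, compound 3 thus stands at the weak end of what this assay can resolve, with no number of its own.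

Compound 4 `Cc1cc(-c2noc([C@H](C)NC(=O)c3cc(C(F)(F)F)nn3C)n2)ccn1` differs from compound 3 in one place: 2-methylpyridin-4-yl in place of 6-methylpyridin-2-yl on an aromatic carbon. The same atoms are joined differently, so that the ring nitrogen and the methyl group sit elsewhere on the six-membered ring that hangs from the five-membered aromatic ring with two nitrogen and one oxygen. Among the compounds with values here, no step between two measured compounds matches this change, so nothing here tells how far it moves this assay, in either direction. Compound 4 is therefore expected to stay weak, with an estimated value of 20000 nM, between 5000 nM and 60000 nM. This expectation implies an at least 1.5-fold lower number from compound 3 to compound 4 (0.17 log units; that floor lies within the scatter), a step not expected to exceed the scatter.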

Compound 4, half-maximal inhibitory concentration: 165 nM
Beside the measured number, compound 4's estimate is 120-fold (2.08 log units) above it; measured number outside the range, below it.
By their numbers in this assay, from the lowest: compound 4; then compound 2; then compound 1. At a limit, above all of these: compound 3.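

In this assay, the position on the five-membered aromatic ring, between two ring nitrogen atoms, responds strongly to how its six-membered ring is arranged: with the same atoms joined differently, the change gives an at least 180-fold lower number from compound 3 to compound 4 (2.25 log units; beyond the scatter). Within the data shown here, no two of the earlier compounds differ in one place, so this is the first step that can be read. Its printed size is only a floor, because compound 3 stands at a limit of the assay: the limit of > 30000 nM in this assay, at which 1 of the 4 values shown sits.

The change moves the ring nitrogen and the methyl group together, so the compounds shown do not tell which of the two accounts for the step. As far as these compounds go, it also remains open how a pyridin-4-yl group without the methyl, or a 2-methoxypyridin-4-yl group, would read at this position.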